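Cytotoxicity notes: trifluoromethyl in place of chloro

The source may hold more compounds than are shown below. What is called first, only, known or untested is meant among the compounds shown, and "the series" means these compounds.

Measured in a functional assay on CEM-SS cells (Homo sapiens) for cytotoxicity; on this read-out higher numbers stand for weaker inhibition and lower numbers for stronger inhibition:
Compound 1 `Nc1nc2cc(Cl)c(Cl)cc2n1Cc1ccc(Cl)cc1`: 32000 nM
Compound 2 `Clc1ccc(Cn2c(Br)nc3cc(Cl)c(Cl)cc32)cc1`: > 100000 nM (a limit)
Compound 3 `Clc1ccc(Cn2c(Br)nc3cc(Cl)c(Cl)cc32)cc1Cl`: > 100000 nM (a limit)

Compound 2 stands only at the limit > 100000 nM and has no number. Compound 4 `FC(F)(F)c1ccc(Cn2c(Br)nc3cc(Cl)c(Cl)cc32)cc1` has trifluoromethyl in place of chloro on an aromatic carbon here, trifluoromethyl in place of chloro on an aromatic carbon. For the measured compounds named here, two measured steps bear on it only loosely: an at least 3.1-fold higher number from compound 1 to compound 2 (0.49 log units; beyond the scatter) for bromo in place of amino, and a step that the two limits leave unreadable from compound 2 to compound 3 for chloro in place of hydrogen. Neither exchanges that chloro. In this assay no step beyond the scatter is expected, given that compound 2 sits at the limit > 100000 nM with no direction to read from it. The estimate gives a number no higher from compound 2 to compound 4 (the limit leaves the size open) as the expected step. For compound 4 the estimated value is 100000 nM with an expected range from 40000 nM to 250000 nM.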

Compound 4, half-maximal inhibitory concentration: > 100000 nM
Compound 4 ended at the assay's limit (the forecaster's own chance of this, stated with the estimate: 70%); the middle value sits exactly at the limit.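

Compound 2 and compound 4 both stand at a limit in this assay, so no step between them can be read: the limit of > 100000 nM in this assay, at which 3 of the 4 values shown sit.

From the compounds shown here alone, whether trifluoromethyl in place of chloro changes cytotoxicity at all, and in which direction, stays open.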